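Four close relatives in a cytotoxicity test

This account rests on a few compounds, and the source may have more. Where it says the series, first, only, none or still open, it means among the compounds named here.

In a functional assay on HeLa cells (Homo sapiens) for cytotoxicity, read by MTT assay (on this read-out higher numbers stand for weaker inhibition and lower numbers for stronger inhibition), compound 3 (`CCC(CO[C@H](CC=C(C)C)C1=CC(=O)c2c(O)ccc(O)c2C1=O)OC(C)=O`) gives 44000 nM. Compound 1 (`CC(C)=CC[C@@H](OC(=O)CCO)C1=CC(=O)c2c(O)ccc(O)c2C1=O`) gives 67600 nM, and compound 2 (`CCCCC(O)CC(=O)O[C@H](CC=C(C)C)C1=CC(=O)c2c(O)ccc(O)c2C1=O`) gives 72200 nM. Compound 3 therefore stands level with both of the others, since the two steps that reach it are small: a 1.5-fold lower number from compound 1 to compound 3 (0.19 log units; within the scatter), and a 1.6-fold lower number from compound 2 to compound 3 (0.22 log units; within the scatter).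

Compound 4 (`CC[C@@](C)(O)CC(=O)O[C@H](CC=C(C)C)C1=CC(=O)c2c(O)ccc(O)c2C1=O`) has the same atoms as compound 3, joined differently, with (2-hydroxy-2-methylbutyl)carbonyl in place of 2-acetoxybutyl on an oxygen on a saturated carbon. For the measured compounds named here, no measured step makes exactly this exchange. The closest are the two steps above, which swap 2-acetoxybutyl against (2-hydroxyethyl)carbonyl in compound 1 and against (2-hydroxyhexyl)carbonyl in compound 2. Both stayed within the scatter. The chain on the carbonyl side also made no clear difference between the two esters: a 1.1-fold higher number from compound 1 to compound 2 (0.03 log units; within the scatter).

Going by the values given here, with only three compounds measured, this is thin evidence, but it gives no reason to expect a step beyond the scatter in this assay, and compound 4 is expected to fall among compound 1, compound 2 and compound 3. The estimated step is a 1.4-fold higher number from compound 3 to compound 4 (0.13 log units; within the scatter). For compound 4 the estimated value is 60000 nM, with an expected range of 30000 nM to 115000 nM.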

Compound 4, half-maximal inhibitory concentration: 17900 nM
Beside the measured number, compound 4's estimate is 3.4-fold (0.53 log units) above it, outside the stated range (below it).
By their numbers in this assay, from the lowest: compound 4; then compounds 3, 1 and 2 (each within the scatter of the next).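

In this assay, for the compounds shown here, the change on an oxygen on a saturated carbon now moves the number beyond the scatter for the first time: (2-hydroxy-2-methylbutyl)carbonyl in place of 2-acetoxybutyl gives a 2.5-fold lower number from compound 3 to compound 4 (0.39 log units; beyond the scatter), although the two groups hold the same atoms, joined differently. The chain on the carbonyl side, which had made no clear difference in a 1.1-fold higher number from compound 1 to compound 2 (0.03 log units; within the scatter), also matters once it carries 1-hydroxy-1-methylpropyl: in place of 1-hydroxypentyl this gives a 4.0-fold lower number from compound 2 to compound 4 (0.61 log units; beyond the scatter), and in place of hydroxymethyl it gives a 3.8-fold lower number from compound 1 to compound 4 (0.58 log units; beyond the scatter), so compound 4 is the most potent of the four in this test, though all three steps are modest. Nothing available explains why this group lowers the number.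

The compounds shown do not separate the part played by the extra methyl on the hydroxyl-bearing carbon from that of the defined stereocentre, and the opposite configuration at that centre remains open. As far as these compounds go, it is also open whether a methoxy group or an amine in place of the hydroxyl of 1-hydroxy-1-methylpropyl, or a longer chain on that same carbon, would keep the number as low.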